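This account rests on a few compounds, and the source may have more. Where it says the series, first, only, none or still open, it means among the compounds named here.

In an ADME assay on BHK-21 cells (Mesocricetus auratus) for cytotoxicity, read by MTT assay, with a stated time of 72 h (on this read-out higher numbers stand for lower toxicity in this test and lower numbers for higher toxicity in this test), compound 1 (`Cc1ccccc1C1CC(c2ccc(OCc3ccccc3)cc2)=NN1c1ccc(S(N)(=O)=O)cc1`) gives 20000 nM. Compound 3 (`NS(=O)(=O)c1ccc(N2N=C(c3ccc(Oc4ccccc4)cc3)CC2c2cccc(F)c2)cc1`) gives 10000 nM, which lies within the usual scatter of compound 1. Compound 2 (`Cc1ccc(C2CC(c3ccccc3)=NN2c2ccc(S(N)(=O)=O)cc2)cc1`) gives 7000 nM, a lower number than compound 1 by more than the scatter. Compound 1 therefore stands at the top of this small set, level with compound 3 within the scatter.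

Compound 4 (`NS(=O)(=O)c1ccc(N2N=C(c3ccc(OCc4ccccc4)cc3)CC2c2ccccc2F)cc1`) changes one place in compound 1: fluoro in place of methyl on an aromatic carbon. This is fluoro in place of methyl on an aromatic carbon, so 2-methylphenyl becomes 2-fluorophenyl. For the measured compounds named here, no two measured compounds differ in one place only, so the data offer no direct guide to this swap. The three measured values do lie fairly close together, and compound 3 at 10000 nM sits near compound 1. A small step in this assay is therefore expected, slightly downward and not beyond the scatter. The expected change is a 1.3-fold lower number from compound 1 to compound 4 (0.12 log units; within the scatter). For compound 4 the estimated value is 15000 nM, with an expected range from 7000 nM to 30000 nM.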

Compound 4, half-maximal cytotoxic concentration: 90000 nM
Compound 4: middle estimate off by 6.0-fold (0.78 log units), on the low side; the whole stated range lies below it.
By their numbers in this assay, from the lowest: compounds 2, 3 and 1 (each within the scatter of the next, the first and the last beyond it); then compound 4.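

Replacing methyl with fluoro on this aromatic carbon, ortho to a large group, gives a 4.5-fold higher number from compound 1 to compound 4 (0.65 log units; beyond the scatter) in this assay, which here stands for lower toxicity in this test. For the compounds shown here, this is the first one-place comparison in the set, and it shows that the read-out responds to a change of a single atom at this place, turning 2-methylphenyl into 2-fluorophenyl. Nothing available here accounts for the size or direction of this step.

Going by these compounds alone, with only one pair to go on, it remains open whether this swap would give a similar step on another member of the series or elsewhere on the ring. As far as these compounds go, how chloro, methoxy, an amine or a carboxylic acid at the same place would read also remains open.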